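Working notes on the aromatic amine substituent series

This account rests on a few compounds, and the source may have more. Where it says the series, first, only, none or still open, it means among the compounds named here.

The series shares the core of compound 1 `N#Cc1cnc(NCc2cnccc2C(F)(F)F)cc1N[C@H]1C[C@@H](O)C1` and varies the group on the aromatic amine nitrogen. In an assay on isolated protein for inhibition of protein kinase C delta type (Homo sapiens), read by TR-FRET, with a stated time of 2 h (a higher number here means a weaker inhibitor, a lower number a stronger inhibitor), compound 1 returns only the assay limit, > 10000 nM. Compound 2 `N#Cc1cnc(NCc2cnccc2C(F)(F)F)cc1NC[C@H]1C[C@H](O)C1` likewise returns only the assay limit in this assay, > 10000 nM. Among the measured compounds shown here, compound 3 `N#Cc1cnc(NCc2cnccc2C(F)(F)F)cc1N[C@H]1CC[C@H](O)CC1` is the one member with a number: in this assay compound 3 gives 6500 nM. The step that the two limits leave unreadable from compound 1 to compound 2 cannot be read, since both ends sit at the limit of > 10000 nM in this assay, at which 2 of the 3 values shown sit. The steps of an at least 1.5-fold lower number from compound 1 to compound 3 (0.18 log units; that floor lies within the scatter) and an at least 1.5-fold lower number from compound 2 to compound 3 (0.18 log units; that floor lies within the scatter) are read only as floors, and both floors lie within the scatter.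

Compound 2 therefore stands at the weak end of what is shown, with a limit rather than a number of its own. Compound 4 `N#Cc1cnc(NCc2cnccc2C(F)(F)F)cc1NCCC1CCOCC1` differs from compound 2 in this way: (oxan-4-yl)methyl in place of 3-hydroxycyclobutyl on a saturated chain carbon bound to a nitrogen on an aromatic ring. For the measured compounds named here, no measured step covers this change; the only measured step leaving compound 2 leads to compound 3 and is itself a floor within the scatter. The measured steps give no ground to expect compound 4 to move beyond the limit that compound 2 shows, so the expected step is a step that the limit leaves unreadable from compound 2 to compound 4, nothing readable beyond the scatter. In this assay compound 4 is estimated at 15000 nM, between 5000 nM and 50000 nM, with a limit the more likely report.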

Compound 4, half-maximal inhibitory concentration: > 10000 nM
Compound 4 ended at the assay's limit (the forecaster's own chance of this, stated with the estimate: 70%); the middle value is on the limit's open side.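

In this assay compound 4 returns only a limit of the assay, > 10000 nM, so a 2-(oxan-4-yl)ethyl group, with 0 hydrogen-bond donors, joins the hydroxy-bearing groups of compound 1 and compound 2 at that limit. The steps linking compound 4 with compound 1 and with compound 2 cannot be read, and most of the series now sits at a single ceiling: the limit of > 10000 nM in this assay, at which 3 of the 4 values shown sit. Among the compounds shown here, the only readable new step is an at least 1.5-fold higher number from compound 3 to compound 4 (0.18 log units; that floor lies within the scatter), so among the groups on this nitrogen, with or without a hydroxyl, the change still shows no difference beyond the scatter.

For the compounds shown here, compound 3 remains the only member with a number, and it remains open whether an amine or a carboxylic acid in place of the hydroxyl of its 4-hydroxycyclohexyl group would give a number clear of the limit. Also open, from the compounds shown here alone, is whether a longer chain ending in a hydroxyl, or a plain cyclohexyl group on the same nitrogen, would separate from the limit in this assay.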